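This account rests on a few compounds, and the source may have more. Where it says the series, first, only, none or still open, it means among the compounds named here.

Measured so far in a functional assay on MOLT-4 cells (Homo sapiens) for antiproliferative activity, with a stated time of 48 h; on this read-out lower numbers stand for stronger inhibition and higher numbers for weaker inhibition:
compound 1 `Nc1ccc(/C=C/C(=O)c2ccccc2)cc1`: 10000 nM
compound 2 `Cc1ccc(C(=O)/C=C/c2ccc(N)cc2)cc1`: 12000 nM

For the measured compounds named here, on these numbers, compound 2 12000 nM stands level with compound 1, the only other compound measured, as the gap between them lies within the usual scatter. The next compound, compound 3 `CCOc1ccc(C(=O)/C=C/c2ccc(N)cc2)cc1`, keeps the shared core and changes a single group: ethoxy in place of methyl on an aromatic carbon. That is ethoxy in place of methyl on an aromatic carbon, para to a large group.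

Going by the values given here, only one measured step bears on this change, and only in part. It is a 1.2-fold higher number from compound 1 to compound 2 (0.08 log units; within the scatter), where methyl took the place of hydrogen on an aromatic carbon, and it stayed within the scatter. Among the compounds with values here, no measured compound carries ethoxy, so this single small step is weak evidence, and it points to no clear direction. No step beyond the scatter is therefore expected, although the uncertainty is wide. The expected change is a 1.2-fold lower number from compound 2 to compound 3 (0.08 log units; within the scatter). In this assay the estimate for compound 3 is 10000 nM, with an expected range from 4000 nM to 25000 nM.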

Compound 3, half-maximal inhibitory concentration: 11000 nM
Beside the measured number, compound 3's estimate is 1.1-fold (0.04 log units) below it; the range from low to high includes it.
By their numbers in this assay, from the lowest: compounds 1, 3 and 2 (each within the scatter of the next).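

In this assay the aromatic carbon para to a large group has now carried hydrogen, methyl and ethoxy, and the three compounds stand level. Ethoxy in place of methyl gives a 1.1-fold lower number from compound 2 to compound 3 (0.04 log units; within the scatter) and ethoxy in place of hydrogen gives a 1.1-fold higher number from compound 1 to compound 3 (0.04 log units; within the scatter) and both steps stay within the scatter. The earlier pair compared only methyl with hydrogen, whereas this result adds a group with more heavy atoms and a hydrogen-bond acceptor, and the number still does not move beyond the scatter. No measurement is available that would explain this flat result, so it remains an observation without a known cause.

These three substituents do not show whether any group at this position can move the number beyond the scatter, and a carboxylic acid, a dimethylamino group or a longer chain such as butoxy would test that more widely. On these data alone, it also remains open whether a change elsewhere on the shared core would have a larger effect on the antiproliferative read-out than these changes at this position.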